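Trimming a Thiocarbamate Side Group on a Shared Core

A few compounds are considered here, and "the series" means these few. Any claim that something is new, unique, unknown or untested is made for them only; others in the source may bear on it.

Measured compounds:
- compound 1, `Nc1ccccc1NC(=O)c1ccc(CSC(=S)N2CCc3cc(Cl)ccc32)cc1`: 65.1%
- compound 2, `Nc1ccccc1NC(=O)c1ccc(CSC(=S)N2CCN(Cc3cccnc3)CC2)cc1`: 78%

Of the compounds shown here, two sharing one core have been tested in a functional assay on HeLa cells (Homo sapiens) for antiproliferative activity, read by CCK-8 assay, with a stated time of 72 h, tested at 8 uM; a higher number here means a stronger effect of the compound at the concentration tested, a lower number a weaker effect. Compound 1 shows 65.1%, the lower of the two numbers, while compound 2 reaches 78%, a value that sits beyond the scatter above compound 1. Among the compounds with values here, no single-point step between these two has been worked out, so the pair only shows that compound 2 gives the larger read-out.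

Compound 3, `Nc1ccccc1NC(=O)c1ccc(CSC(=S)N2CCCC2)cc1`, is not yet measured. Relative to compound 1 it carries one change: pyrrolidin-1-yl in place of 5-chloro-2,3-dihydro-1H-indol-1-yl on a thiocarbonyl carbon. Within the data shown here, the group that enters is the smaller of the two, and nothing among the measured compounds isolates this kind of swap on its own.

The expected step from compound 1 to compound 3 in this assay is a number 7.1 percentage points lower from compound 1 to compound 3 (within the scatter), a modest drop that may well stay within the scatter. Compound 3 is therefore estimated at 58%, with a range from 38% to 78%.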

Compound 3, a percentage reported as inhibition, at one concentration (the size of the read-out at that concentration, not a potency): 77.8%
Compound 3: the middle estimate sits 19.8 percentage points below what was measured; low and high end bracket the measured number.
By their numbers in this assay, from the lowest: compound 1; then compounds 3 and 2 (each within the scatter of the next).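

On the thiocarbonyl carbon, pyrrolidin-1-yl in place of 5-chloro-2,3-dihydro-1H-indol-1-yl gives in this assay a number 12.7 percentage points higher from compound 1 to compound 3 (beyond the scatter). Within the data shown here, this is the first step measured at this position, and it shows that, for this pair, removing the chlorine-bearing aromatic ring and going from 10 heavy atoms to 5 does not lower the read-out at the concentration tested. Nothing available accounts for why the read-out moves with this change.

From the compounds shown here alone, whether an open-chain diethylamino group or a morpholin-4-yl ring on the same thiocarbonyl carbon would keep this read-out remains open. Going by these compounds, the step also comes from a single concentration, so how the two compounds compare in potency is still unknown.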